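The compounds below may be only part of what the source reports. "The series", "measured", "known", "first", "only" and "open" are said of these compounds alone.

Working notes on a series of four ureas sharing a piperidine amide arrangement.

Compound 1 `O=C(Nc1ccc(OC(F)(F)F)c(F)c1)NC1CCN(C(=O)C2CC2)CC1` in a physicochemical assay for lipophilicity, read by HPLC, with a stated time of 90 min, tested at 100 uM (a lower number here means a more polar compound, a higher number a more lipophilic compound), gives 4.19. Compound 2 `O=C(Nc1ccc(C(F)(F)F)c(F)c1)NC1CCN(C(=O)C2CC2)CC1` differs from compound 1 at one place: trifluoromethyl in place of trifluoromethoxy on an aromatic carbon. The measured step is a number 0.25 log units lower from compound 1 to compound 2 (within the scatter).

Compound 3 `O=C(Nc1ccc(OC(F)(F)F)cc1)NC1CCN(C(=O)[C@@H]2CCOC2)CC1` is built on a different core from compound 1; the difference between the two cores is not broken down here. In this assay compound 2 gives 3.94. In this assay compound 3 gives 3.38, the lowest of the three numbers, standing beyond the scatter from both compound 2 and compound 1.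

Compound 4 `O=C(Nc1ccc(C(F)(F)F)cc1)NC1CCN(C(=O)[C@@H]2CCOC2)CC1` has not yet been measured. It differs from compound 3 as follows: trifluoromethyl in place of trifluoromethoxy on an aromatic carbon. This is the same kind of change as that from compound 1 to compound 2, not the same: around the place in compound 1 the group also stands ortho to a fluoro group (1 heavy atom), which compound 3 lacks. For the measured compounds named here, the step is expected to be a number 0.23 log units lower from compound 3 to compound 4 (within the scatter), resting on the single measured instance, a number 0.25 log units lower from compound 1 to compound 2 (within the scatter). In this assay compound 4 is therefore estimated at 3.15, expected to fall between 2.85 and 3.45.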

Compound 4, partition coefficient: 3.27
Compound 4: the middle estimate sits 0.12 log units below what was measured; low and high end bracket the measured number.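

In this assay, trifluoromethyl in place of trifluoromethoxy gives a number 0.11 log units lower from compound 3 to compound 4 (within the scatter), and the same change on the other core gives a number 0.25 log units lower from compound 1 to compound 2 (within the scatter). The change therefore carries across the two cores shown without a step on either that can be told from scatter, but this does not show that the change has a real effect on either core, and with one pair per core it says nothing about any further core. The fluoro group present on the aromatic ring of one pair and absent from the other cannot be separated from the other differences between the cores, and no measurement on hand offers an explanation for either step.

Still open, from the compounds shown here alone, is how a nitrile or a carboxylic acid on the same aromatic carbon would read in this assay. Also open, going by these compounds, is whether the step would stay within the scatter on a core carrying an amine.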